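The compounds below may be only part of what the source reports. "The series", "measured", "known", "first", "only" and "open" are said of these compounds alone.

Measured compounds in the series:

Compound 1 `O=C(Nc1cccc(Oc2ccccn2)c1)C1CCCN(C(=O)c2cc(C(F)(F)F)cc(C(F)(F)F)c2)C1` gives 0% in an ADME assay on PC-3 cells (Homo sapiens) for cytotoxicity, read by WST assay, tested at 100 uM; a lower number here means less inhibition, a higher number more inhibition at the concentration tested (going by the name of the read-out).
Compound 2 `CC(C)(C)OC(=O)c1cccc(NC(=O)C2CCCN(C(=O)c3cc(C(F)(F)F)cc(C(F)(F)F)c3)C2)c1` gives 0% in this assay.
Compound 3 `O=C(Nc1cccc(S(=O)(=O)N2CCCC2)c1)C1CCCN(C(=O)c2cc(C(F)(F)F)cc(C(F)(F)F)c2)C1` gives 0% in this assay.

All three share the same core and differ only in the group on the aromatic carbon of the anilide ring. Every measured step is flat: no change at the digits printed from compound 1 to compound 2 (within the scatter), no change at the digits printed from compound 1 to compound 3 (within the scatter) and no change at the digits printed from compound 2 to compound 3 (within the scatter). For the measured compounds named here, compound 3 therefore stands level with compounds 1 and 2, with no measured compound showing any inhibition at the tested concentration.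

Compound 4 `COc1cccc(NC(=O)C2CCCN(C(=O)c3cc(C(F)(F)F)cc(C(F)(F)F)c3)C2)c1` is the next member. Its difference from compound 3 is methoxy in place of (pyrrolidin-1-yl)sulfonyl on an aromatic carbon, meta to a large group. The bearing steps are those at the same position: tert-butoxycarbonyl for (pyridin-2-yl)oxy, (pyrrolidin-1-yl)sulfonyl for (pyridin-2-yl)oxy, and (pyrrolidin-1-yl)sulfonyl for tert-butoxycarbonyl, none of them moving the read-out beyond the scatter. Three unrelated groups at this carbon left the result unchanged, so a fourth is expected to behave the same way, with a step of no change at the digits printed from compound 3 to compound 4 (within the scatter) expected. For compound 4 the estimated value in this assay is 0%, with a range from 0% to 10%.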

Compound 4, a percentage reported as inhibition, at one concentration (the size of the read-out at that concentration, not a potency): 0%
The estimate for compound 4 equals the measured number at the digits printed, and the stated range covers the measured number.
By their numbers in this assay, from the lowest: compounds 1, 2, 3 and 4 (each within the scatter of the next).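

Compound 4 puts a group of only 2 heavy atoms, with no ring, on this aromatic carbon, and replacing the 8 heavy atoms and five-membered non-aromatic ring of (pyrrolidin-1-yl)sulfonyl in this assay gives no change at the digits printed from compound 3 to compound 4 (within the scatter). Methoxy in place of tert-butoxycarbonyl gives no change at the digits printed from compound 2 to compound 4 (within the scatter), while methyl in place of pyridin-2-yl gives no change at the digits printed from compound 1 to compound 4 (within the scatter), a step that keeps the oxygen on the aromatic ring and changes only what that oxygen carries. No supporting data bear on why the read-out stays flat across these changes.

Going by these compounds, whether an amine, a carboxylic acid or a longer alkoxy chain at this carbon would also leave this assay unchanged remains open. Also open, on these data alone, is whether changing a trifluoromethyl group or the shared core would shift the read-out, and with all four compounds level, the series gives no ranking of the groups at this position.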